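This account rests on a few compounds, and the source may have more. Where it says the series, first, only, none or still open, it means among the compounds named here.

Compound 1 `Cc1ccc(-c2ccc(C)n2-c2ccc(-c3nc4ccccc4s3)cc2)cc1` — 17800 nM
Compound 2 `COc1ccc(-c2ccc(C)n2-c2ccc(-c3nc4ccccc4s3)cc2)cc1` — 14800 nM
Compound 3 `Cc1ccc(-c2ccc([N+](=O)[O-])cc2)n1-c1ccc(-c2nc3ccccc3s2)cc1` — 12100 nM

In a functional assay on MDA-MB-231 cells (Homo sapiens) for cytotoxicity, read by MTT assay, with a stated time of 72 h (on this read-out higher numbers stand for weaker inhibition and lower numbers for stronger inhibition), compound 1 gives the highest of the three numbers, yet only by steps within the scatter: a 1.2-fold lower number from compound 1 to compound 2 (0.08 log units; within the scatter) and a 1.5-fold lower number from compound 1 to compound 3 (0.17 log units; within the scatter). Compound 4 `Cc1ccc(-c2ccc(C)n2-c2ccc(-c3nc4ccc(F)cc4s3)cc2)cc1` differs from compound 1 by fluoro in place of hydrogen on an aromatic carbon. Among the measured compounds shown here, none of the measured steps touches that part of the shared core; all three exchange a group elsewhere, and each stayed within the scatter, including a 1.2-fold lower number from compound 2 to compound 3 (0.09 log units; within the scatter). They therefore bear on compound 4 only by showing how little the series has moved so far, and no step beyond the scatter is expected in this assay. Compound 4 is estimated at 16000 nM, with a range from 7000 nM to 36000 nM, which means an expected 1.1-fold lower number from compound 1 to compound 4 (0.05 log units; within the scatter).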

Compound 4, half-maximal inhibitory concentration: 16700 nM
For compound 4 the middle estimate is 1.0-fold (0.02 log units) below the measured one; the range from low to high includes it.
By their numbers in this assay, from the lowest: compounds 3, 2, 4 and 1 (each within the scatter of the next).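

In this assay fluoro in place of hydrogen on an aromatic carbon, the only change shown at this part of the shared core, gives a 1.1-fold lower number from compound 1 to compound 4 (0.03 log units; within the scatter) and so adds this position to those where no step beyond the scatter has been seen. That reading rests on a single fluoro. Nothing available explains the result.

Going by these compounds, whether an amine, a carboxylic acid or a longer chain at this position would move the number beyond the scatter remains open. So does whether fluoro here would give a similar step on compound 2 or compound 3.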